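A few compounds are considered here, and "the series" means these few. Any claim that something is new, unique, unknown or untested is made for them only; others in the source may bear on it.

Measured so far:
compound 1, `Cc1ccc(-c2c(S(=O)(=O)c3ccccc3)cnc3c(Br)c(-c4ccccc4)nn23)cc1`, 6.6% 
compound 2, `Cc1ccc(-c2c(S(=O)(=O)c3ccccc3)cnc3cc(-c4ccccc4)nn23)cc1`, 15.5% 

These two compounds were tested in a functional assay on the whole organism for inhibition, with Mus musculus as the target, with a stated time of 6 h, at a dose of 50 mg/kg by the oral route; a higher number here means more inhibition at the dose given (going by the name of the read-out), a lower number less inhibition. Compound 2 gives 15.5%, and compound 1 gives 6.6%; the step of a number 8.9 percentage points higher from compound 1 to compound 2 (within the scatter), so on the numbers shown compound 2 cannot be separated from compound 1, and the inhibition in this assay is level for the pair.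

Compound 3, `Cc1ccc(-c2cc3ncc(S(=O)(=O)c4ccccc4)c(-c4ccc(C)cc4)n3n2)cc1`, has not yet been measured. It differs from compound 2 in one place: methyl in place of hydrogen on an aromatic carbon.

Going by the values given here, no measured step bears directly on this change. Among the compounds with values here, the only step recorded, from compound 1 to compound 2, concerns a different alteration and was within the scatter. There is therefore nothing in the data pointing to a shift of either sign for compound 3, and the expectation is for a step of a number 0.5 percentage points lower from compound 2 to compound 3 (within the scatter) in this assay, that is, none beyond the scatter.

Compound 3 is accordingly estimated at 15% in this assay, with a range from 3% to 35%.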

Compound 3, a percentage reported as inhibition, in the whole organism at one dose (the size of the read-out at that dose, not a potency): 11.6%
Beside the measured number, compound 3's estimate is 3.4 percentage points above it, and the stated range covers the measured number.
By their numbers in this assay, from the lowest: compounds 1, 3 and 2 (each within the scatter of the next).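

The change from phenyl to 4-methylphenyl, on an aromatic carbon of a six-membered aromatic ring of carbon only and para to a large group, comes with a number 3.9 percentage points lower from compound 2 to compound 3 (within the scatter) in this assay. Going by these compounds alone, the earlier pair spoke only to bromo on an aromatic carbon of the shared core, so this is the first reading for this position, and at this dose the added methyl gives a number that cannot be told apart from that of the parent compound. Nothing measured here bears on what the methyl does at this position, and the result comes with no supporting data on any property of these compounds.

The compounds shown leave open whether a different group on this same carbon, such as an amine, a carboxylic acid or a longer chain, would give a step beyond the scatter in this assay. They also leave open whether a methyl in this position would read the same way on a core carrying bromo, as compound 1 does.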